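The source may report more compounds than this note shows. Statements on the series, on what has been measured and on what is new or still open speak of the compounds shown alone.

Measured compounds:
Compound 1, `COc1cc(/C=C/C(=O)/C=C(/C=C/c2ccc(O)c(OC)c2)NCCCO)ccc1O`: 75700 nM
Compound 2, `COCCNC(=C\C(=O)/C=C/c1ccc(O)cc1)/C=C/c1ccc(O)cc1`: 28000 nM

Both compounds were tested in a functional assay on Caco-2 cells (Homo sapiens) for cytotoxicity, read by MTT assay, with a stated time of 48 h; a lower number here means a stronger inhibitor, a higher number a weaker inhibitor. Of the two numbers measured, compound 2 gives the lower one, 28000 nM, and compound 1 gives the higher one, 75700 nM; the gap between them lies beyond the usual scatter of repeated measurements, so compound 2 is the stronger inhibitor of the pair.

Compound 3, `COCCCNC(=C\C(=O)/C=C/c1ccc(O)cc1)/C=C/c1ccc(O)cc1`, has not yet been measured. It differs from compound 2 in one place only: methoxymethyl in place of methoxy on a saturated chain carbon, two bonds along the chain from an amine nitrogen. The two phenol-bearing arms and the central chain that carries the carbonyl and the amine are kept unchanged; only the tail on the amine nitrogen grows by one saturated carbon.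

For the measured compounds named here, no step of this kind between two measured compounds is available here, so the expectation rests on the change itself. Lengthening the tail by a single carbon is expected to move the number little, if at all, so the step of a 1.1-fold higher number from compound 2 to compound 3 (0.03 log units; within the scatter) is estimated to stay within the scatter. Compound 3 is therefore estimated to give about 30000 nM, with a range from 12000 nM to 75000 nM.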

Compound 3, half-maximal inhibitory concentration: 24000 nM
For compound 3 the middle estimate is 1.3-fold (0.10 log units) above the measured one; the range from low to high includes it.
By their numbers in this assay, from the lowest: compounds 3 and 2 (each within the scatter of the next); then compound 1.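

In this assay, replacing the 2-methoxyethyl group on the amine nitrogen with 3-methoxypropyl gives a 1.2-fold lower number from compound 2 to compound 3 (0.07 log units; within the scatter). For the compounds shown here, this is the first direct reading of a change at this position, as compound 1 and compound 2 differ in more than one place and their gap cannot be tied to the tail on the nitrogen. For this single pair, the longer tail, with its ether oxygen further out along the chain, leaves the number unchanged within the scatter, and nothing available here offers an explanation for that result.

As far as these compounds go, one step at one position cannot show how far this tolerance reaches, so it remains open whether a longer chain such as 5-methoxypentyl would also leave the number unchanged. Also open, from the compounds shown here alone, is whether the ether oxygen matters at all, which a plain propyl or butyl chain could test, and whether a tail ending in an amine or a carboxylic acid would move the number beyond the scatter.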